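The source may report more compounds than this note shows. Statements on the series, on what has been measured and on what is new or still open speak of the compounds shown alone.

In an in vitro ADME assay on microsomes from liver (Homo sapiens) for metabolic stability (a lower number here means slower removal, a higher number faster removal of the compound), compound 1 `CC(C)NC(=O)[C@H]1CC[C@@H](n2/c(=N/C(=O)c3ccc(F)cc3)[nH]c3ccc(CN4CCC[C@H]4C(C)(C)O)cc32)CC1` gives 569 mL.min-1.g-1 while compound 2 `CC(C)NC(=O)[C@H]1CC[C@@H](n2/c(=N/C(=O)c3ccc(F)c(F)c3)[nH]c3ccc(CN4CCC(C(C)(C)O)CC4)cc32)CC1` gives 60 mL.min-1.g-1 and so holds the lower of the two numbers. That gap lies beyond the usual scatter of repeat measurements. However, the two compounds differ in more than one place, so it cannot be pinned on any single change.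

Compound 3 `CC(C)NC(=O)[C@H]1CC[C@@H](n2/c(=N/C(=O)c3ccccc3)[nH]c3ccc(CN4CCC(C(C)(C)O)CC4)cc32)CC1` departs from compound 2 in one place only, with phenyl in place of 3,4-difluorophenyl on a carbonyl carbon. Cut one bond further out, the same difference reads as (3,4-difluorophenyl)carbonyl turning into benzoyl. Within the data shown here, no measured pair of compounds isolates this swap, so the data offer no direct guide to its size. The expectation in this assay is therefore modest: a slight rise in the number, if any, that stays within the scatter. The estimated change is a 1.2-fold higher number from compound 2 to compound 3 (0.07 log units; within the scatter) on this reading. For compound 3 the expected intrinsic clearance in microsomes is 70 mL.min-1.g-1 (estimated range 35 mL.min-1.g-1 to 140 mL.min-1.g-1).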

Compound 3, intrinsic clearance in microsomes: 40 mL.min-1.g-1
Estimate against measurement, compound 3: 1.8-fold (0.24 log units) above; the range from low to high includes it.
By their numbers in this assay, from the lowest: compounds 3 and 2 (each within the scatter of the next); then compound 1.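

In this assay putting phenyl in place of 3,4-difluorophenyl on a carbonyl carbon gives a 1.5-fold lower number from compound 2 to compound 3 (0.18 log units; within the scatter) and so leaves the two compounds indistinguishable in this read-out. Among these compounds, this is the first pair that differs in one place only, which means a single change can now be read on its own: with the rest of the structure held the same, the ring on this carbonyl carbon can lose both fluorine atoms with no clear shift in intrinsic clearance. Nothing available speaks to the reason for this result.

This single pair says nothing about whether the swap would read the same way with the different side chain that compound 1 carries, so the result holds for the structure shared by compound 2 and compound 3 alone. It also leaves open how far this position tolerates other groups, such as a pyridine ring on the carbonyl carbon, or a phenyl ring bearing a methoxy group or a nitrile.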